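Cytotoxicity of a benzofuran ketone series on liver cells

A few compounds are considered here, and "the series" means these few. Any claim that something is new, unique, unknown or untested is made for them only; others in the source may bear on it.

Compound 1 `CCN(CC)c1ccc2cc(C(=O)c3ccc(N4CCN(C(=O)CN5CCN(C(=O)CCl)CC5)CC4)cc3)oc2c1` — 20900 nM
Compound 2 `CCN(CC)c1ccc2cc(C(=O)c3ccc(N4CCN(C(=O)CN5CCN(C(=O)/C=C/c6ccccc6)CC5)CC4)cc3)oc2c1` — > 100000 nM
Compound 3 `CCN(CC)c1ccc2cc(C(=O)c3ccc(N4CCN(C(=O)CN5CCN(Cc6ccc(/C=C/C(=O)OC)cc6)CC5)CC4)cc3)oc2c1` — > 100000 nM

Of the compounds shown here, three sharing one core have been tested in an ADME assay on L02 cells (Homo sapiens) for cytotoxicity, read by MTT assay, with a stated time of 48 h; on this read-out higher numbers stand for weaker inhibition and lower numbers for stronger inhibition. Compound 1 gives 20900 nM. For compound 2 the read-out is a limit of the assay, > 100000 nM, not a number. For compound 3 the read-out is likewise a limit, > 100000 nM. Within the data shown here, the one step that can be sized, an at least 4.7-fold higher number from compound 1 to compound 2 (0.67 log units; beyond the scatter), moves away from cytotoxicity; its true size is hidden by the limit of > 100000 nM in this assay, at which 2 of the 3 values shown sit.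

Compound 4 `CCN(CC)c1ccc2cc(C(=O)c3ccc(N4CCN(C(=O)CN5CCN(Cc6ccc(F)c(F)c6)CC5)CC4)cc3)oc2c1` is not yet measured. It differs from compound 3 in one place: 3,4-difluorophenyl in place of 4-(2-(methoxycarbonyl)ethenyl)phenyl on a saturated chain carbon bound to an amine nitrogen in a ring. Among the measured compounds shown here, no measured step touches the group on that carbon, so the only guide is where compound 3 stands, which is at a limit. Both compounds that carry a phenyl-bearing group rather than the chloromethyl of compound 1 sit at the same limit, and compound 4 keeps a phenyl-bearing group there. It is therefore expected that compound 4 remains weakly cytotoxic, with a step of a number no higher from compound 3 to compound 4 (the limit leaves the size open) meaning no change beyond the scatter. The estimate for compound 4 in this assay is 100000 nM, within 40000 nM to 200000 nM.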

Compound 4, half-maximal inhibitory concentration: 10200 nM
Beside the measured number, compound 4's estimate is 9.8-fold (0.99 log units) above it, outside the stated range (below it).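

At the saturated chain carbon bound to an amine nitrogen in a ring, the group proves to matter in this assay: 3,4-difluorophenyl in place of 4-(2-(methoxycarbonyl)ethenyl)phenyl gives an at least 9.8-fold lower number from compound 3 to compound 4 (0.99 log units; beyond the scatter), so a phenyl-bearing group at this place does not by itself hold the read-out at the limit. Viewed as a change on the amine nitrogen in a ring, 3,4-difluorobenzyl in place of (2-phenylethenyl)carbonyl gives an at least 9.8-fold lower number from compound 2 to compound 4 (0.99 log units; beyond the scatter), and 3,4-difluorobenzyl in place of (chloromethyl)carbonyl gives a 2.0-fold lower number from compound 1 to compound 4 (0.31 log units; beyond the scatter), so the chloromethyl group is not needed for a number in this range. The first two of these steps give only a least size, because each starts from a limit: the limit of > 100000 nM in this assay, at which 2 of the 4 values shown sit.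

The compounds shown do not separate the effect of the two fluorines from that of losing the ester-bearing chain; a plain benzyl, a 4-fluorobenzyl or a carboxylic acid in place of the methyl ester would bear on that question. From the compounds shown here alone, how the read-out responds to other groups on this ring, such as a nitrile or an amine, also remains open.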